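Biphenyl amide replaces difluorophenyl amide on a hydroxyflavone

The source may report more compounds than this note shows. Statements on the series, on what has been measured and on what is new or still open speak of the compounds shown alone.

Compound 1 `COc1cccc(C(=O)Nc2cccc(-c3oc4cc(-c5ccc(F)cc5)ccc4c(=O)c3O)c2)c1`: 9950 nM
Compound 2 `CCc1ccc(C(=O)Nc2cccc(-c3oc4cc(-c5ccc(F)cc5)ccc4c(=O)c3O)c2)cc1`: 20600 nM
Compound 3 `O=C(Nc1cccc(-c2oc3cc(-c4ccc(F)cc4)ccc3c(=O)c2O)c1)c1cc(F)cc(F)c1`: 4960 nM

Three amides of a shared hydroxyflavone core were tested in a functional assay on HepG2 cells (Homo sapiens) for antiproliferative activity, read by CCK-8 assay, with a stated time of 72 h; a higher number here means a weaker inhibitor, a lower number a stronger inhibitor. Compound 3 gives the lowest of the three numbers; its neighbour compound 1 sits at a 2.0-fold lower number from compound 1 to compound 3 (0.30 log units; within the scatter), which is within the scatter, while compound 2 lies furthest away, at a 4.2-fold lower number from compound 2 to compound 3 (0.62 log units; beyond the scatter), which is beyond it. Compound 1 and compound 2 are separated by a 2.1-fold higher number from compound 1 to compound 2 (0.32 log units; beyond the scatter).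

Compound 4 `O=C(Nc1cccc(-c2oc3cc(-c4ccc(F)cc4)ccc3c(=O)c2O)c1)c1ccc(-c2ccccc2)cc1` is not yet measured. It differs from compound 3 in one place: 4-phenylphenyl in place of 3,5-difluorophenyl on a carbonyl carbon. Within the data shown here, the steps that bear on this change are the two that alter the same aryl group on the carbonyl carbon, namely a 2.0-fold lower number from compound 1 to compound 3 (0.30 log units; within the scatter) and a 4.2-fold lower number from compound 2 to compound 3 (0.62 log units; beyond the scatter); both leave compound 3 with the lowest number, and the 4-substituted aryl of compound 2 gave the highest. A modest rise in this assay is therefore expected for compound 4, roughly a 3.0-fold higher number from compound 3 to compound 4 (0.48 log units; beyond the scatter). The estimated value for compound 4 is 15000 nM, with a plausible range from 5000 nM to 45000 nM.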

Compound 4, half-maximal inhibitory concentration: 88500 nM
The estimate for compound 4 lay 5.9-fold (0.77 log units) below the measured number, and the stated range ends below it.
By their numbers in this assay, from the lowest: compounds 3 and 1 (each within the scatter of the next); then compound 2; then compound 4.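

In this assay, the 4-phenylphenyl group on the carbonyl carbon shows that this position can tolerate far less than the earlier modest steps suggested, giving an 18-fold higher number from compound 3 to compound 4 (1.25 log units; beyond the scatter), a large step. Phenyl in place of ethyl on an aromatic carbon still gives a 4.3-fold higher number from compound 2 to compound 4 (0.63 log units; beyond the scatter), and with an 8.9-fold higher number from compound 1 to compound 4 (0.95 log units; beyond the scatter) compound 4 ends as the weakest of the four, so adding a second aromatic ring to the aryl group raises the number well beyond the level of compound 2. Nothing among the measurements at hand accounts for this rise.

The compounds shown leave open whether the number would stay near that of compound 3 or climb toward that of compound 4 with an amine or a carboxylic acid on the aryl group. They also leave open what a single fluorine or a longer alkyl chain would give there.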